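A few compounds are considered here, and "the series" means these few. Any claim that something is new, unique, unknown or untested is made for them only; others in the source may bear on it.

Working notes on the series. Compound 3 `COC(=O)C1=C(C)N(C)C(=O)NC1c1ccsc1` gives 24% in an assay on membranes from CHO cells for displacement of a labelled ligand from adenosine receptor A1 (Homo sapiens), read by scintillation counting, with a stated time of 60 min, tested at 1 uM (on this read-out higher numbers stand for more inhibition at the one concentration tested (going by the name of the read-out) and lower numbers for less inhibition), the highest of the three numbers measured; compound 2 `CCCOC(=O)C1=C(C)N(C)C(=O)NC1c1cccs1` stands nearest with 9%, and compound 1 `CCCOC(=O)C1=C(C)N(C)C(=O)NC1c1ccco1` furthest with 3%. Among the measured compounds shown here, the one single-point step measured so far, a number 6 percentage points higher from compound 1 to compound 2 (within the scatter), concerns the heteroaryl group on the shared core and lies within the scatter. Compound 2 and compound 3 differ in two places, so their two values are only noted side by side.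

Compound 4 `CCCOC(=O)C1=C(C)N(C)C(=O)NC1c1ccsc1` is obtained from compound 3 by the change (ethyl in place of hydrogen on a saturated chain carbon bound to an oxygen next to a carbonyl group), read one bond further out as methoxycarbonyl to propoxycarbonyl. For the measured compounds named here, no measured step alters this ester chain, so nothing here speaks for a shift beyond the scatter in either direction; the only evidence on the propoxycarbonyl compounds is that compound 1 and compound 2 both show low inhibition, though each also carries a different heteroaryl group than compound 3. The expected step is a number 4 percentage points lower from compound 3 to compound 4 (within the scatter), within the scatter. Compound 4 is therefore estimated at 20%, with a range from 5% to 35%.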

Compound 4, a percentage reported as inhibition, at one concentration (the size of the read-out at that concentration, not a potency): 2%
The estimate for compound 4 lay 18 percentage points above the measured number; measured number outside the range, below it.
By their numbers in this assay, from the lowest: compounds 4, 1 and 2 (each within the scatter of the next); then compound 3.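

Among the compounds shown here, with thiophen-3-yl held fixed, this is the first measured change of the ester chain: in this assay methoxycarbonyl to propoxycarbonyl gives a number 22 percentage points lower from compound 3 to compound 4 (beyond the scatter), so the ester chain on the shared core can move this read-out beyond the scatter. With propoxycarbonyl held fixed, the heteroaryl group gives a number 7 percentage points lower from compound 2 to compound 4 (within the scatter) and a number 1 percentage points lower from compound 1 to compound 4 (within the scatter), so thiophen-3-yl, thiophen-2-yl and furan-2-yl are not told apart on this ester, and the number of compound 3 stands out only with methoxycarbonyl. No measurement at hand bears on the reason for the step from the methoxycarbonyl to the propoxycarbonyl compound.

Going by these compounds, it remains open whether the ester step carries over to furan-2-yl or thiophen-2-yl on the saturated ring carbon. Also open, on these data alone, is how an ethyl ester, a butyl ester or a carboxylic acid would read in this place.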